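The compounds below may be only part of what the source reports. "The series", "measured", "known", "first", "only" and "open" are said of these compounds alone.

Of the compounds shown here, two that share a common core have been measured in a functional assay on the whole organism for inhibition, with Digitaria ciliaris as the target, with a stated time of 72 h, tested at 100 mg/L; on this read-out lower numbers stand for less inhibition of growth and higher numbers for more inhibition of growth at the one concentration tested. Compound 1 `Cc1onc(-c2ccc(Cl)cc2Cl)c1C(=O)/N=c1/nc2nc(Cl)cc(C)n2s1` gives 68.1% in this assay. Compound 2 `COc1cc(OC)nc(NC(=S)NC(=O)c2c(-c3ccc(Cl)cc3Cl)noc2C)n1` gives 65.9% in this assay. Compound 1 thus holds the higher of the two numbers, but its gap to compound 2 lies within the scatter of repeated measurements, so the two cannot be set in order on these data.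

Compound 3 `COc1cc(Cl)nc2n/c(=N/C(=O)c3c(-c4ccc(Cl)cc4Cl)noc3C)sn12` has not yet been measured. It differs from compound 1 in one place: methoxy in place of methyl on an aromatic carbon. Among the compounds with values here, no measured pair in this set shows the effect of such a change, so no step size can be read from the data. With both measured compounds standing close together, a change of one small group at this position is expected to move the number little, in no particular direction and not beyond the scatter.

Compound 3 is therefore expected to give about 65%, with a range from 50% to 80%. This estimate means a step of a number 3.1 percentage points lower from compound 1 to compound 3 (within the scatter), expected to stay within the scatter.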

Compound 3, percent growth inhibition at one concentration: 72.8%
Estimate against measurement, compound 3: 7.8 percentage points below, within the range that was stated.
By their numbers in this assay, from the lowest: compounds 2, 1 and 3 (each within the scatter of the next).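

Within the data shown here, the exchange of methyl for methoxy on an aromatic carbon, next to the ring nitrogen, gives the first step that can be read at this position: in this assay it amounts to a number 4.7 percentage points higher from compound 1 to compound 3 (within the scatter). This step lies within the scatter, so compound 1 and compound 3 cannot be set in order, and the methoxy group, with its hydrogen-bond acceptor, leaves growth inhibition at the one concentration tested indistinguishable from that seen with methyl. Nothing in the available data bears on the reason for this result.

The two groups shown here are small and closely related, so it remains open whether the position would respond to an amine, a carboxylic acid or a longer chain such as butoxy with a step beyond the scatter. The single concentration also leaves open whether compound 1 and compound 3 would separate across a range of concentrations, or against other weed species, so this one step describes only the narrow case of methyl and methoxy in this assay.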